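Shortening the alkoxy chain: isopentyloxy to isobutoxy

The source may hold more compounds than are shown below. What is called first, only, known or untested is meant among the compounds shown, and "the series" means these compounds.

Values in a functional assay on NUGC-3 cells (Homo sapiens) for antiproliferative activity, read by sulforhodamine B assay; a lower number here means a stronger inhibitor of growth, a higher number a weaker inhibitor of growth:
- compound 1 `CC(C)CCCOc1cccc(O)c1C(=O)/C=C/c1ccc(O)cc1`: 3520 nM
- compound 2 `CC(C)CCOc1cccc(O)c1C(=O)/C=C/c1ccc(O)cc1`: 12400 nM

Of the two measured compounds, compound 2 has the higher number and is the weaker inhibitor of growth in this assay, at 12400 nM. The next structure to consider is compound 3 `CC(C)COc1cccc(O)c1C(=O)/C=C/c1ccc(O)cc1`. The change is isopropyl in place of isobutyl on a saturated chain carbon bound to an oxygen on an aromatic ring. In words, isopropyl stands in place of isobutyl on a saturated chain carbon bound to an oxygen on an aromatic ring. Cut one bond further out, the same difference reads isopentyl to isobutyl.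

Within the data shown here, only one measured step bears on this change: a 3.5-fold higher number from compound 1 to compound 2 (0.55 log units; beyond the scatter). That step is the same replacement, made two bonds along the chain from the oxygen on the aromatic ring rather than on the carbon bound to it. It is modest but beyond the scatter. With a single precedent, a step of similar size in the same direction is expected, though with wide uncertainty. The expected change is a 2.4-fold higher number from compound 2 to compound 3 (0.38 log units; beyond the scatter). For compound 3 the estimated value is 30000 nM, within an expected range of 11000 nM to 80000 nM.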

Compound 3, concentration for 50% growth inhibition: 2980 nM
Beside the measured number, compound 3's estimate is 10-fold (1.00 log units) above it, and the stated range ends above it.
By their numbers in this assay, from the lowest: compounds 3 and 1 (each within the scatter of the next); then compound 2.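

Working notes: in this assay, the replacement of isobutyl by isopropyl on a saturated chain carbon bound to an oxygen on an aromatic ring gives a 4.2-fold lower number from compound 2 to compound 3 (0.62 log units; beyond the scatter), whereas the same replacement further along the chain gave a 3.5-fold higher number from compound 1 to compound 2 (0.55 log units; beyond the scatter), so this change has no single direction across the series. The ends of the set match within the scatter, with a 1.2-fold lower number from compound 1 to compound 3 (0.07 log units; within the scatter), and compound 2, with its isopentyloxy chain, is the weakest of the three in this assay, so chain length does not track growth inhibition in a steady way here. Nothing on hand accounts for this reversal in the direction of the step.

Going by these compounds, it remains open whether the weak result for compound 2 reflects a narrow dependence on this exact chain or is a local feature of these three branched chains, which an unbranched n-pentyl chain at the same oxygen could help separate. Also open, on these data alone, is how far the chain can shrink or change in type, for example with a methoxy or ethoxy group, or with a terminal amine or carboxylic acid on the chain.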